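This account rests on a few compounds, and the source may have more. Where it says the series, first, only, none or still open, it means among the compounds named here.

Compound 2 `CNc1nc(Cl)nc2c1ncn2[C@@H]1O[C@H](C(=O)NCC2CC2)[C@@H](O)[C@H]1O` carries a cyclopropylmethyl group on its amide nitrogen, whereas compound 1 `CNc1nc(Cl)nc2c1ncn2[C@@H]1O[C@H](C(=O)NC2CC2)[C@@H](O)[C@H]1O` carries a cyclopropyl group there. In an assay on CHO cells for displacement of a labelled ligand from adenosine receptor A3 (Homo sapiens) (a higher number here means a weaker inhibitor, a lower number a stronger inhibitor), compound 1 gives 2.82 nM, and compound 2 gives 1.1 nM, the lower of the two numbers, with a 2.6-fold lower number from compound 1 to compound 2 (0.41 log units; beyond the scatter). Compound 3 `Cc1ccccc1CNc1nc(Cl)nc2c1ncn2[C@@H]1O[C@H](C(=O)NCC2CC2)[C@@H](O)[C@H]1O` is compound 2 altered elsewhere: 2-methylphenyl in place of hydrogen on a saturated chain carbon bound to a nitrogen on an aromatic ring. Within the data shown here, the single measured step between compounds concerns the amide nitrogen and does not touch this position, so the data give no direct guide to the size or direction of the step to expect in this assay. The change adds a ring at the amino group while the rest of compound 2 stays intact, and compound 3 is expected to stay close to compound 2, with a step of a 1.8-fold higher number from compound 2 to compound 3 (0.26 log units; within the scatter) that may fall within the scatter. The estimate for compound 3 is 2 nM, within a range of 0.4 nM to 10 nM.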

Compound 3, inhibition constant: 29.5 nM
Estimate against measurement, compound 3: 15-fold (1.17 log units) below; the measured number lies above the stated range.
By their numbers in this assay, from the lowest: compound 2; then compound 1; then compound 3.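

In this assay, this position proves far more sensitive than the amide nitrogen: going from methylamino to (2-methylbenzyl)amino gives a 27-fold higher number from compound 2 to compound 3 (1.43 log units; beyond the scatter), whereas the change on the amide nitrogen gave a 2.6-fold lower number from compound 1 to compound 2 (0.41 log units; beyond the scatter). The added 2-methylphenyl group therefore costs a clear loss of strength, although compound 3 still gives a measurable 29.5 nM. Nothing measured here explains why the number climbs so far at this position.

Going by these compounds, it remains open whether this loss comes from the ring itself, from the methyl group on it, or simply from a larger group at this nitrogen; a plain benzyl group or a short chain such as ethyl would help separate these possibilities. On these data alone, it is also open whether the step would be the same size with the cyclopropyl amide of compound 1.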